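Triazole acetamide series: para substituent swap, compound 3 to compound 4

The source may report more compounds than this note shows. Statements on the series, on what has been measured and on what is new or still open speak of the compounds shown alone.

The series shares the core of compound 1 `O=C(Cn1cc(-c2ccccc2Cl)nn1)Nc1nc2ccccc2s1` and varies the aryl group on the triazole. In a functional assay on BMDM cells (Mus musculus, strain C57BL/6) for inhibition, with a stated time of 2 days (on this read-out lower numbers stand for stronger inhibition and higher numbers for weaker inhibition), compound 1 gives only a limit of the assay, > 30000 nM. Compound 2 `O=C(Cn1cc(-c2cccs2)nn1)Nc1nc2ccccc2s1` gives 21400 nM in this assay. Among the compounds with values here, the one measured single-point step, an at least 1.4-fold lower number from compound 1 to compound 2 (0.14 log units; that floor lies within the scatter), arises from thiophen-2-yl in place of 2-chlorophenyl on an aromatic carbon. Compound 3 `COC(=O)c1ccc(-c2cn(CC(=O)Nc3nc4ccccc4s3)nn2)cc1` stands only at a limit in this assay, > 30000 nM, so no number is available for it; this is reflected in the limit of > 30000 nM in this assay, at which 2 of the 3 values shown sit.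

Compound 4 `O=C(Cn1cc(-c2ccc(F)cc2)nn1)Nc1nc2ccccc2s1` differs from compound 3 by fluoro in place of methoxycarbonyl on an aromatic carbon. Within the data shown here, no measured step concerns a change of a substituent on the six-membered aromatic ring of carbon only; the step from compound 1 to compound 2 exchanges the whole aryl ring and is itself only a floor within the scatter, so it offers no direction for the present change. With both compound 3 and compound 1 at the limit and compound 2 barely inside the measurable range, the expectation is that compound 4 stays weak in this assay. Compound 4 is therefore estimated at 30000 nM, with a range of 8000 nM to 100000 nM, and the expected step of a number no higher from compound 3 to compound 4 (the limit leaves the size open) is not resolved beyond the scatter, with a fair chance that only a limit is again reported.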

Compound 4, half-maximal inhibitory concentration: > 30000 nM
Compound 4: no number, only a limit (the forecaster's own chance of this, stated with the estimate: 55%); the middle value sits exactly at the limit.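

With fluoro in place of methoxycarbonyl on an aromatic carbon para to a large group, this assay still gives no number, so two substituents as different as one of 4 heavy atoms with 2 hydrogen-bond acceptors and one of 1 heavy atom with 0 hydrogen-bond acceptors both end at a limit. The steps to compound 4 from compound 3 and from compound 1 join two limits and cannot be read. The one readable step is an at least 1.4-fold higher number from compound 2 to compound 4 (0.14 log units; that floor lies within the scatter), which does not separate 4-fluorophenyl from thiophen-2-yl, and the series stays at the edge of the read-out: the limit of > 30000 nM in this assay, at which 3 of the 4 values shown sit.

From the compounds shown here alone, whether any substituent at this place gives a measurable number remains open, for instance an amine or a carboxylic acid in place of fluoro. With a single number among the compounds shown, it also remains open whether the aryl group on the triazole can move this read-out at all, or whether a change elsewhere on the shared core would do more.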